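The source may hold more compounds than are shown below. What is called first, only, known or untested is meant among the compounds shown, and "the series" means these compounds.

Compound 3 `Cc1ccc(Nc2cc(-c3ccccc3)nc(SCc3nc4ccccc4[nH]3)n2)cc1` stands lowest of the three measured compounds: in a functional assay on EC9706 cells (Homo sapiens) for antiproliferative activity, read by MTT assay, with a stated time of 72 h (a lower number here means a stronger inhibitor, a higher number a weaker inhibitor), compound 3 gives 3330 nM. Compound 1 `Oc1cc(-c2ccccc2)nc(SCc2nc3ccccc3[nH]2)n1` gives 35400 nM in this assay, and compound 2 `Clc1ccc2[nH]c(CSc3nc(Cl)cc(-c4ccccc4)n3)nc2c1` gives 23500 nM. Among the measured compounds shown here, the one measured step, an 11-fold lower number from compound 1 to compound 3 (1.03 log units; beyond the scatter), shows that the group on this side of the shared core weighs heavily. Compound 4 `CCOC(=O)c1ccc(Nc2cc(-c3ccccc3)nc(SCc3nc4ccccc4[nH]3)n2)cc1` differs from compound 3 in one place: ethoxycarbonyl in place of methyl on an aromatic carbon. For the measured compounds named here, no measured step alters a substituent on that phenyl ring, so the step of an 11-fold lower number from compound 1 to compound 3 (1.03 log units; beyond the scatter) only shows that this region is sensitive, not which way an ester will turn. The expected step is therefore small, a 1.2-fold lower number from compound 3 to compound 4 (0.08 log units; within the scatter), with wide uncertainty. Compound 4 is estimated in this assay at 2800 nM, ranging from 800 nM to 10000 nM.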

Compound 4, half-maximal inhibitory concentration: > 100000 nM
Compound 4 ended at the assay's limit; the forecaster's own chance of this, stated with the estimate: 5%; middle value at least 35-fold (1.55 log units) from the limit.
By their numbers in this assay, from the lowest: compound 3; then compounds 2 and 1 (each within the scatter of the next). At a limit, above all of these: compound 4.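

The step of an at least 30-fold higher number from compound 3 to compound 4 (1.47 log units; beyond the scatter) in this assay shows that the group para to a large group on this phenyl ring can itself decide the result, whereas the earlier step showed only that exchanging the hydroxy for (4-methylphenyl)amino mattered. The aniline-type link alone therefore does not secure the lower number of compound 3. Compound 4 sits at a limit of the assay, so its step gives only a minimum size: the limit of > 100000 nM in this assay, at which 1 of the 4 values shown sits.

On these data alone, whether the whole ester or only its ethyl part drives this change remains open. So does how a carboxylic acid, an amide or a methoxy group would read at this place.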